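Trimethoxyphenyl in place of methoxyphenyl on compound 2

The compounds below may be only part of what the source reports. "The series", "measured", "known", "first", "only" and "open" are said of these compounds alone.

Working notes on the series. In a functional assay on 786-0 cells (Homo sapiens) for inhibition (on this read-out lower numbers stand for stronger inhibition of growth and higher numbers for weaker inhibition of growth), compound 2 `COc1ccc(-c2cn(-c3cccc(C(=O)/C=C/c4cc(OC)c(OC)c(OC)c4)c3)c(=O)[nH]2)cc1` gives 1610 nM, the lowest of the three numbers; compound 1 `COc1cc(/C=C/C(=O)c2cccc(-n3cc(-c4ccc(Cl)cc4)[nH]c3=O)c2)ccc1O` gives 2070 nM, within the scatter of compound 2, while compound 3 `COc1ccc(-c2cn(-c3cccc(C(=O)/C=C/c4ccc(O)c(OC)c4)c3)c(=O)[nH]2)cc1` gives 4530 nM, beyond it. Compound 4 `COc1cc(/C=C/C(=O)c2cccc(-n3cc(-c4cc(OC)c(OC)c(OC)c4)[nH]c3=O)c2)cc(OC)c1OC` differs from compound 2 thus: 3,4,5-trimethoxyphenyl in place of 4-methoxyphenyl on an aromatic carbon. Within the data shown here, two measured steps bear on it: a 2.2-fold higher number from compound 1 to compound 3 (0.34 log units; beyond the scatter), on an aromatic carbon, and a 2.8-fold higher number from compound 2 to compound 3 (0.45 log units; beyond the scatter), on a double-bonded chain carbon. Neither places 3,4,5-trimethoxyphenyl where 4-methoxyphenyl leaves, and both were modest. No step beyond the scatter is therefore expected in this assay for compound 4, at most a slight drift upward, a 1.2-fold higher number from compound 2 to compound 4 (0.09 log units; within the scatter). Compound 4 is estimated at 2000 nM, with a range of 800 nM to 5000 nM.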

Compound 4, concentration for 50% growth inhibition: 1590 nM
Estimate against measurement, compound 4: 1.3-fold (0.10 log units) above, within the range that was stated.
By their numbers in this assay, from the lowest: compounds 4, 2 and 1 (each within the scatter of the next); then compound 3.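

On an aromatic carbon of the five-membered aromatic ring with 2 nitrogen, the larger 3,4,5-trimethoxyphenyl can replace 4-methoxyphenyl with no change outside the scatter in this assay: a 1.0-fold lower number from compound 2 to compound 4 (0.01 log units; within the scatter). The number therefore stays level here despite the added heavy atoms and hydrogen-bond acceptors, with 3,4,5-trimethoxyphenyl also present on the chain in both compounds. No measured evidence accounts for this result.

Open, on these data alone, is whether an amine or a carboxylic acid on this phenyl ring would keep the number level. Also open, as far as these compounds go, is whether an unsubstituted phenyl would do so.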